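Chloro to Iodo on a Shared Core

The source may report more compounds than this note shows. Statements on the series, on what has been measured and on what is new or still open speak of the compounds shown alone.

Of the compounds shown here, two have so far been measured in a functional assay (spleen, spleen) for activation, with Mus musculus as the target; on this read-out lower numbers stand for an effect already at smaller amounts and higher numbers for an effect only at larger amounts of compound. Compound 1, `COc1ccc(Cn2c(O)nc3c(N)ncnc32)cc1`, gives 10 uM in this assay. Compound 2, `Nc1ncnc2c1nc(Cl)n2Cc1ccccc1`, yields only a limit of the assay rather than a number: in this assay compound 2 gives > 10 uM. Compound 2 thus stands at the limit of > 10 uM in this assay, at which 1 of the 2 values shown sits. Within the data shown here, no two measured compounds differ in just one place, so no measured step between them is available.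

Compound 3, `Nc1ncnc2c1nc(I)n2Cc1ccccc1`, has not yet been measured. The change from compound 2 to compound 3 is iodo in place of chloro on an aromatic carbon. Since compound 2 sits at a limit and no measured step of this kind exists among the compounds shown, the size of the step in this assay cannot be read from the data. The expectation is that compound 3 remains close to compound 2, with no shift beyond the scatter, and that a limit is again the most likely outcome. The step from compound 2 to compound 3 is expected to be a step that the limit leaves unreadable from compound 2 to compound 3. Compound 3 is estimated at 15 uM, within a range from 4 uM to 60 uM.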

Compound 3, minimum effective concentration: > 10 uM
Compound 3: no number, only a limit; the forecaster's own chance of this, stated with the estimate: 60%; the middle value does not contradict the limit.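

In this assay, compound 2 and compound 3 both end at a limit of the assay rather than at a number, so iodo in place of chloro gives no step that can be read: the limit of > 10 uM in this assay, at which 2 of the 3 values shown sit.

The compounds shown leave open how far apart compound 2 and compound 3 truly lie, and at what amount either one takes effect.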